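The source may report more compounds than this note shows. Statements on the series, on what has been measured and on what is new or still open speak of the compounds shown alone.

In a functional assay on A549 cells (Homo sapiens) for inhibition (on this read-out lower numbers stand for stronger inhibition and higher numbers for weaker inhibition), compound 1 `Oc1ccc(/C=C/c2ccc3ccccc3c2)cc1` gives 4060 nM. Compound 2 `FC(F)(F)Oc1cccc(/C=C\c2ccc3ccccc3c2)c1` gives 3500 nM, which lies within the scatter of the value for compound 1. For compound 3 `Cc1ccc(/C=C\c2ccc3ccccc3c2)cc1`, the assay reports only a limit, > 5000 nM. For the measured compounds named here, these results place compound 1 among the few measured numbers, but no measured pair differs in one place, so none shows the effect of a single change. Compound 4 `CN(C)c1ccc(/C=C/c2ccc3ccccc3c2)cc1` carries dimethylamino in place of hydroxy on an aromatic carbon, para to a large group: dimethylamino in place of hydroxy on an aromatic carbon. In this assay, no step beyond the scatter is expected. The estimated step of a 1.2-fold lower number from compound 1 to compound 4 (0.06 log units; within the scatter) is correspondingly small. For compound 4, the expected value is 3500 nM, with an estimated range of 1200 nM to 8000 nM.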

Compound 4, half-maximal inhibitory concentration: 3660 nM
Beside the measured number, compound 4's estimate is 1.0-fold (0.02 log units) below it, within the range that was stated.
By their numbers in this assay, from the lowest: compounds 2, 4 and 1 (each within the scatter of the next). At a limit, above all of these: compound 3.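

In this assay, for the compounds shown here, the step of a 1.1-fold lower number from compound 1 to compound 4 (0.05 log units; within the scatter) is the first single-place comparison, and it concerns dimethylamino in place of hydroxy on an aromatic carbon, para to a large group. This change removes the hydrogen-bond donor of hydroxy and adds heavy atoms, yet the step stays within the scatter. Compound 3 is reported only as a limit: the limit of > 5000 nM in this assay, at which 1 of the 4 values shown sits.

The compounds shown leave open whether a methoxy group, a primary amine or a carboxylic acid at this position would give a step beyond the scatter.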